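A few compounds are considered here, and "the series" means these few. Any claim that something is new, unique, unknown or untested is made for them only; others in the source may bear on it.

Measured so far in a functional assay on HCT-116 cells (Homo sapiens) for antiproliferative activity, read by MTT assay, with a stated time of 48 h; a higher number here means a weaker inhibitor, a lower number a stronger inhibitor:
compound 1 `N#CC1=C(N)Oc2c(c3nc4ccccc4nc3c3ccccc23)C12C(=O)N(Cc1cnnn1-c1cccc(Cl)c1)c1ccccc12` gives > 50000 nM, which is a limit of the assay and not a number.
compound 2 `N#CC1=C(N)Oc2c(N)cc3nc4ccccc4nc3c2C12C(=O)N(Cc1cnnn1-c1ccccc1Cl)c1ccccc12` gives > 50000 nM, likewise a limit and not a number.

Compound 2 therefore stands nowhere in particular on these figures: both values shown in this assay sit at the same limit, as the evidence states, (the limit of > 50000 nM in this assay, at which 2 of the 2 values shown sit), and neither compound can be ranked against the other on that basis. Compound 2 carries an amine on its shared core and a 2-chlorophenyl on the triazole nitrogen, and the assay reports only that its half-maximal inhibitory concentration lies beyond what was tested.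

Compound 3 `COc1ccc(OC)c(-n2nncc2CN2C(=O)C3(C(C#N)=C(N)Oc4c(N)cc5nc6ccccc6nc5c43)c3ccccc32)c1` differs from compound 2 in one place:
2,5-dimethoxyphenyl in place of 2-chlorophenyl on an aromatic nitrogen

Among the measured compounds shown here, no step between measured compounds has been measured, so the size of this change cannot be read from any pair in hand. For the measured compounds named here, with the only two values shown resting at the limit, no step beyond the scatter is expected in this assay from the change. The step from compound 2 to compound 3 is expected to be a step that the limit leaves unreadable from compound 2 to compound 3. Compound 3 is estimated at 60000 nM, with a range from 25000 nM to 150000 nM, and most likely to be reported again only as a limit.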

Compound 3, half-maximal inhibitory concentration: > 50000 nM
Compound 3 ended at the assay's limit; the forecaster's own chance of this, stated with the estimate: 80%; the middle value does not contradict the limit.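

Compound 3 gives > 50000 nM in this assay and that is a limit of the assay, not a number. Among the compounds shown here, no step from compound 2 to compound 3 can be read, since the values shown all rest at one limit: the limit of > 50000 nM in this assay, at which 3 of the 3 values shown sit. The compounds shown leave open whether 2,5-dimethoxyphenyl and 2-chlorophenyl differ at all in this assay, and what on the shared core would give a readable value.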